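Acyl replacement on the cyclohexyl ester anilide series

This account rests on a few compounds, and the source may have more. Where it says the series, first, only, none or still open, it means among the compounds named here.

Measured so far in a functional assay on MCF7 cells (Homo sapiens) for inhibition, read by MTT assay, with a stated time of 72 h; a lower number here means a stronger inhibitor, a higher number a weaker inhibitor:
compound 1 `O=C(OC1(C(=O)Nc2ccc([N+](=O)[O-])cc2)CCCCC1)c1ccc(C(F)(F)F)cc1` gives 27.1 nM;
compound 2 `O=C(OC1(C(=O)Nc2ccc([N+](=O)[O-])cc2)CCCCC1)c1ccccc1I` gives 619 nM;
compound 3 `CCOC(=O)c1ccccc1C(=O)OC1(C(=O)Nc2ccc([N+](=O)[O-])cc2)CCCCC1` gives 444 nM.

Compound 2 holds the highest number of the three. Compound 3 sits nearest to it, and the two lie within the usual scatter of each other, so no order between them is claimed. Compound 1 lies furthest away, with the much lower number of the set.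

Compound 4 `CC(=O)OC1(C(=O)Nc2ccc([N+](=O)[O-])cc2)CCCCC1` has not yet been measured. It differs from compound 2 by methyl in place of 2-iodophenyl on a carbonyl carbon, so the whole aromatic ring of the acyl part is removed and only an acetyl group remains on the ester oxygen.

Two measured steps speak to this region. The step of a 23-fold higher number from compound 1 to compound 2 (1.36 log units; beyond the scatter) shows that exchanging one aryl group for another at the carbonyl carbon can move the number a long way. The step of a 1.4-fold lower number from compound 2 to compound 3 (0.14 log units; within the scatter) shows that changing the substituent on that ring while keeping the ring itself changes little. Neither step removes the ring, so the expected direction is uncertain; with the ring gone, a further rise in the number is judged more likely than a fall.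

Compound 4 is therefore expected to give about 1500 nM, within 250 nM to 9000 nM, which corresponds to an expected step of a 2.4-fold higher number from compound 2 to compound 4 (0.38 log units; beyond the scatter).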

Compound 4, half-maximal inhibitory concentration: 403 nM
Beside the measured number, compound 4's estimate is 3.7-fold (0.57 log units) above it; measured number inside the range.
By their numbers in this assay, from the lowest: compound 1; then compounds 4, 3 and 2 (each within the scatter of the next).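

In this assay the step of a 1.5-fold lower number from compound 2 to compound 4 (0.19 log units; within the scatter) shows that the whole 2-iodophenyl ring can give way to methyl on this carbonyl carbon with no readable change, so an aromatic ring there is not needed to hold the level of compound 2. The step of a 15-fold higher number from compound 1 to compound 4 (1.17 log units; beyond the scatter) ties the low number of compound 1 to the 4-(trifluoromethyl)phenyl group in particular and not to the mere presence of an aromatic ring, a distinction the aryl-for-aryl step alone could not make. No measurement at hand accounts for this one aryl group standing apart from the other acyl groups.

Still open, on these data alone, is which part of the 4-(trifluoromethyl)phenyl group carries the low number, a question that an unsubstituted phenyl or a trifluoroacetyl group on the same ester oxygen would address. Also open, as far as these compounds go, is whether other acyl groups, such as a longer alkyl chain or one bearing an amine or a carboxylic acid, stay at the level of compound 4 or move towards compound 1.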